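The source may hold more compounds than are shown below. What is called first, only, known or untested is meant among the compounds shown, and "the series" means these compounds.

In a functional assay on MOLT-4 cells (Homo sapiens) for antiproliferative activity, with a stated time of 48 h (a lower number here means a stronger inhibitor, a higher number a weaker inhibitor), compound 1 (`C=C(Br)C(=O)Nc1ccc(/C=C/C(=O)c2ccccc2)cc1`) gives 3100 nM and compound 2 (`C=C(Br)C(=O)Nc1ccc(/C=C/C(=O)c2ccc(I)cc2)cc1`) gives 2800 nM, so these two values lie within the scatter of each other. Compound 3 (`C=C(Br)C(=O)Nc1ccc(/C=C/C(=O)c2cccc(OC)c2)cc1`) has not yet been measured. Its structure differs from that of compound 2 as follows: 3-methoxyphenyl in place of 4-iodophenyl on a carbonyl carbon. Within the data shown here, the one measured step that bears on this change is a 1.1-fold lower number from compound 1 to compound 2 (0.04 log units; within the scatter), which adds the iodo group, and that step stays within the scatter. Among the measured compounds shown here, it shows that removing the iodo group alone is not expected to matter much, but no measured compound carries a methoxy group, so the data are thin on that side. No shift beyond the scatter is therefore expected, in either direction, and the estimated move is a 1.1-fold higher number from compound 2 to compound 3 (0.03 log units; within the scatter). For compound 3 the expected value is 3000 nM, with an estimated range of 1200 nM to 7500 nM.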

Compound 3, half-maximal inhibitory concentration: 850 nM
Compound 3: the middle estimate sits 3.5-fold (0.55 log units) above what was measured, and the stated range ends above it.
By their numbers in this assay, from the lowest: compound 3; then compounds 2 and 1 (each within the scatter of the next).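

In this assay the phenyl group on the carbonyl carbon proves able to move the number beyond the scatter, which the iodo step had not shown: 3-methoxyphenyl in place of 4-iodophenyl gives a lower number (a 3.3-fold lower number from compound 2 to compound 3 (0.52 log units; beyond the scatter)) and so does methoxy in place of hydrogen (a 3.6-fold lower number from compound 1 to compound 3 (0.56 log units; beyond the scatter)). Compound 1 and compound 2 lie within the scatter of each other, so the lower number goes with the entry of the methoxy group and not with the loss of the iodo group. Nothing measured here accounts for this shift.

The compounds shown carry the methoxy group at one place on the ring only, so its effect elsewhere on the ring stays open. On these data alone, whether a hydroxy group, an ethoxy group or an amine in its stead would also give a lower number stays open too.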